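Replacing Pyrazine with Pyridine on a Shared Core

This account rests on a few compounds, and the source may have more. Where it says the series, first, only, none or still open, it means among the compounds named here.

Compound 1, `CCC(C)(C)Cc1c[nH]c(CCc2ccc(-c3cnccn3)cc2)n1`, was tested in a functional assay on HEK293 cells for agonist activity at Bombesin receptor subtype-3 (Homo sapiens), read by luminescence and calcium flux, with a stated time of 10 min (a lower number here means that less compound is needed, a higher number that more compound is needed for the effect), where compound 1 gives 431 nM. Among the three compounds measured, compound 1 stands with the highest number. For the measured compounds named here, compound 2, `c1ccc(-c2ccc(CCc3nc(CC4CCCC4)c[nH]3)cc2)nc1`, gives 425 nM, which lies within the usual scatter of the value of compound 1; compound 2 differs from compound 1 in two places at once, so no single step can be drawn between them. Going by the values given here, compound 3, `CCC(C)(C)Cc1c[nH]c(CCc2ccc(-c3cnsc3)cc2)n1`, gives 44 nM, and the single step of a 9.8-fold lower number from compound 1 to compound 3 (0.99 log units; beyond the scatter) shows a clear gain when the six-membered ring is replaced by a five-membered one.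

Compound 4, `CCC(C)(C)Cc1c[nH]c(CCc2ccc(-c3cccnc3)cc2)n1`, has not yet been measured. It differs from compound 1 as follows: pyridin-3-yl in place of pyrazin-2-yl on an aromatic carbon. Among the compounds with values here, only the step from compound 1 to compound 3 bears on this change, and it concerns a different ring, so the bearing is indirect. Since compound 3 shows that altering this ring can lower the number well beyond the scatter, a smaller gain is expected for compound 4, estimated as a 2.2-fold lower number from compound 1 to compound 4 (0.33 log units; beyond the scatter). Compound 4 is therefore expected to give about 200 nM, within a range from 60 nM to 600 nM.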

Compound 4, half-maximal effective concentration: 131 nM
The estimate for compound 4 lay 1.5-fold (0.18 log units) above the measured number; the measured number falls inside the stated range.
By their numbers in this assay, from the lowest: compound 3; then compound 4; then compounds 2 and 1 (each within the scatter of the next).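

In this assay, the step of a 3.3-fold lower number from compound 1 to compound 4 (0.52 log units; beyond the scatter) shows that the number can fall beyond the scatter while a six-membered aromatic ring stays at this position, so the gain seen earlier did not depend on moving to a five-membered ring. With the ring size unchanged, pyridin-3-yl carries one hetero atom where pyrazin-2-yl carries two, yet the step of a 3.0-fold higher number from compound 3 to compound 4 (0.47 log units; beyond the scatter) shows that pyridin-3-yl does not match 1,2-thiazol-4-yl, and the three groups on the shared core therefore fall into a clear order, with 1,2-thiazol-4-yl lowest, pyridin-3-yl in the middle and pyrazin-2-yl highest. No measurement is available that would explain why these rings differ.

For the compounds shown here, with only three groups compared at this position on this core, it remains open whether a plain phenyl ring, with no hetero atom, would continue the fall in the number or reverse it. On these data alone, it is equally open whether an amine or a carboxylic acid added to the pyridin-3-yl ring would bring the number down to that of compound 3 or push it back up.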